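A few compounds are considered here, and "the series" means these few. Any claim that something is new, unique, unknown or untested is made for them only; others in the source may bear on it.

Measured compounds:
- compound 1 `CCCCc1nc(=O)c(S(=O)(=O)c2ccc(-c3ccc(F)cc3)cc2)c(O)n1-c1c(OC)cccc1OC`: in an ADME assay for permeability, using PAMPA, at pH 5.5 (on this read-out higher numbers stand for higher permeability and lower numbers for lower permeability), compound 1 gives 418 nm/s
- compound 2 `CCCCc1[nH]c(=O)c(S(=O)(=O)c2ccc(-c3ccc(F)cc3)cc2)c(O)c1-c1c(OC)cccc1OC`: in this assay compound 2 gives "not determined" (no result reported)

Compound 1 and compound 2 share the same substituents but differ in how the core is built up; only compound 1 carries a number in this assay, and compound 2 stands without one, so no comparison between the two is possible on the numbers shown.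

Compound 3 `CCCCc1[nH]c(=O)c(S(=O)(=O)c2ccc(-c3ccncc3C)cc2)c(O)c1-c1c(OC)cccc1OC` is the next compound in the series and is still to be measured in this assay. It is related to compound 2 by a single change: 3-methylpyridin-4-yl in place of 4-fluorophenyl on an aromatic carbon. Among the measured compounds shown here, no measured pair in this set shows what a change of this kind does in this assay, and compound 2 itself contributes no number, so the direction and size of the step cannot be read from the data at hand; the only anchor is the value of compound 1.

On that basis the permeability of compound 3 in this assay is estimated at 150 nm/s, with a range from 40 nm/s to 500 nm/s, reflecting the missing reference point for compound 2.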

Compound 3, apparent permeability: 355 nm/s
Compound 3: middle estimate off by 2.4-fold (0.37 log units), on the low side; low and high end bracket the measured number.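

No new step can be read in this assay: compound 3 gives 355 nm/s, but compound 2 carries no number to compare it with. The compounds shown leave open what exchanging 4-fluorophenyl for 3-methylpyridin-4-yl does on this read-out, and how the two core arrangements compare. No supporting evidence bears on this result.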